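The compounds below may be only part of what the source reports. "The series", "measured", "known", "first", "only" and "open" are said of these compounds alone.

Measured in a functional assay on HEL cells (Homo sapiens) for cytotoxicity; a lower number here means that less compound is tolerated, a higher number that more compound is tolerated:
- Compound 1 `CCCCCc1cc2cn([C@H]3C[C@H](O)[C@@H](CO)O3)c(=O)nc2o1`: > 50000 nM
- Compound 2 `CCCCCCc1cc2cn([C@H]3C[C@H](O)[C@@H](CO)O3)c(=O)nc2o1`: > 200000 nM
- Compound 3 `CCCCCCCCCCc1cc2cn([C@H]3C[C@H](O)[C@@H](CO)O3)c(=O)nc2o1`: > 50000 nM

Compound 1 gives only a limit, > 50000 nM, and not an exact number. Compound 2 and compound 3 also give only limits. Compound 4 `C#CCCCc1cc2cn([C@H]3C[C@H](O)[C@@H](CO)O3)c(=O)nc2o1` keeps the shared core and changes the chain end, turning pentyl into pent-4-yn-1-yl: ethynyl in place of ethyl on a saturated chain carbon, three bonds along the chain from an aromatic carbon. The closest measured changes also alter this chain: a step that the two limits leave unreadable from compound 1 to compound 2 and a step that the two limits leave unreadable from compound 1 to compound 3. Neither has a readable size, so neither offers a step to carry over, and no shift beyond the scatter is expected in this assay. The expected change is a step that the limit leaves unreadable from compound 1 to compound 4. For compound 4 the estimate is 80000 nM, with an expected range from 30000 nM to 200000 nM.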

Compound 4, half-maximal cytotoxic concentration: > 200000 nM
Compound 4 was reported as a limit (the forecaster's own chance of this, stated with the estimate: 85%); at least 2.5-fold (0.39 log units) between middle value and limit.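

Compound 4, like compound 1, compound 2 and compound 3, gives only a limit, and none of its steps to them can be read. The compounds shown leave open whether changing the chain shifts the tolerated concentration at all.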